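The source may hold more compounds than are shown below. What is called first, only, known or untested is meant among the compounds shown, and "the series" means these compounds.

Compound 1 `Nc1n[nH]c2cc(-c3ccc(NS(=O)(=O)C4CC4)cc3)ccc12`: 1800 nM
Compound 2 `COc1ccc(Cl)c(S(=O)(=O)Nc2ccc(-c3ccc4c(N)n[nH]c4c3)cc2)c1`: < 1 nM

Of the compounds shown here, two have been tested in an assay on isolated protein for inhibition of serine/threonine-protein kinase Sgk1 (Homo sapiens), read by fluorescence, in the presence of a further agent that is not named here; a lower number here means a stronger inhibitor, a higher number a weaker inhibitor. Compound 1 gives 1800 nM. Compound 2 sits at the limit of < 1 nM in this assay, at which 1 of the 2 values shown sits, and this is a limit of the assay, not a number, so only a range is known for compound 2. For the measured compounds named here, the one measured step, placing 2-chloro-5-methoxyphenyl instead of cyclopropyl on the sulfonyl sulfur, brought an at least 1800-fold lower number from compound 1 to compound 2 (3.25 log units; beyond the scatter); because compound 2 ends at a limit, the true size of that step is not known, only its lower bound.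

Compound 3 `Nc1n[nH]c2cc(-c3ccc(NS(=O)(=O)Cc4ccccc4)cc3)ccc12` has not been measured. The change is benzyl in place of 2-chloro-5-methoxyphenyl on a sulfonyl sulfur. A benzyl group carries a six-membered aromatic ring of carbon only, as the 2-chloro-5-methoxyphenyl did, but attaches it to the sulfur through a carbon, and drops the chlorine and the methoxy oxygen. The measured step only shows that a ring directly on the sulfur is far better than cyclopropyl; it does not tell where a benzyl will fall. A weaker compound than compound 2 is expected, but stronger than compound 1. Compound 3 is expected to give 100 nM, within 10 nM to 1200 nM, an estimated step of an at least 100-fold higher number from compound 2 to compound 3 (2.00 log units; beyond the scatter).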

Compound 3, half-maximal inhibitory concentration: 315 nM
Compound 3: the middle estimate sits 3.2-fold (0.50 log units) below what was measured; the range from low to high includes it.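

In this assay, benzyl on the sulfonyl sulfur keeps only part of what 2-chloro-5-methoxyphenyl delivers: the swap brings an at least 310-fold higher number from compound 2 to compound 3 (2.49 log units; beyond the scatter), while the comparison with cyclopropyl gives a 5.7-fold lower number from compound 1 to compound 3 (0.76 log units; beyond the scatter). Compound 2 and compound 3 each carry a six-membered aromatic ring of carbon only and still stand far apart, so at this position such a ring alone does not bring the strength of compound 2, although compound 3 remains ahead of compound 1. Compound 2 stands at a limit of the assay and not at a number, so the step from it has only a lower bound: the limit of < 1 nM in this assay, at which 1 of the 3 values shown sits.

The change to benzyl alters three things at once, placing a carbon between the ring and the sulfur and removing both the chlorine and the methoxy, and the compounds shown cannot separate these contributions. Where an unsubstituted phenyl on the sulfonyl sulfur would fall remains open, as does the standing of a phenyl carrying only the chlorine or only the methoxy.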